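The source may hold more compounds than are shown below. What is called first, only, known or untested is meant among the compounds shown, and "the series" means these compounds.

Measured in a functional assay with Rattus norvegicus as the target; a higher number here means a weaker inhibitor, a lower number a stronger inhibitor:
- compound 1 `COc1cccc2[nH]c(=O)c(=O)oc12`: 7000 nM
- compound 2 `COc1ccc2oc(=O)c(=O)[nH]c2c1`: 15000 nM
- compound 3 `N#Cc1ccc2[nH]c(=O)c(=O)oc2c1`: 15000 nM

Compound 2 stands level with compound 3, and together they hold the highest number of the three. Compound 1 has a lower number, and its gap to compound 2 lies just beyond the usual scatter of repeated measurements.

The next compound is compound 4 `CCOC(=O)c1ccc2oc(=O)c(=O)[nH]c2c1`, which keeps the core of compound 2 and changes a single group: ethoxycarbonyl in place of methoxy on an aromatic carbon.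

Within the data shown here, no two measured compounds differ in only one place, so the data give no direct measure of what a single swap does in this assay. Among the measured compounds shown here, the only guide is the narrow spread of the three values, from compound 1 at 7000 nM to compound 2 at 15000 nM. On that basis, no change beyond the scatter is expected, and no firm direction can be given. The expected 1.2-fold lower number from compound 2 to compound 4 (0.06 log units; within the scatter) is therefore small. Compound 4 is estimated at 13000 nM, with an expected range of 5000 nM to 35000 nM.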

Compound 4, half-maximal inhibitory concentration: 10000 nM
For compound 4 the middle estimate is 1.3-fold (0.11 log units) above the measured one, and the stated range covers the measured number.
By their numbers in this assay, from the lowest: compounds 1, 4, 2 and 3 (each within the scatter of the next, the first and the last beyond it).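

In this assay, putting ethoxycarbonyl in place of methoxy on this aromatic carbon gives a 1.5-fold lower number from compound 2 to compound 4 (0.18 log units; within the scatter), the first direct measure of a single swap in this set, and the two compounds cannot be told apart. This position therefore takes a group with more heavy atoms, more hydrogen-bond acceptors and a double bond outside the aromatic rings without a shift that exceeds the usual scatter, although this rests on one pair of compounds only. Nothing measured here explains why the swap leaves the number within the scatter.

The compounds shown leave open whether a carboxylic acid, an amine or a much longer chain on the same carbon would move the number beyond the scatter, or whether this position accepts almost any group. They also leave open whether the same swap from methoxy to ethoxycarbonyl would behave in the same way on a different carbon of the aromatic ring.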